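Cyano for bromo on the aromatic ring of compound 3

A few compounds are considered here, and "the series" means these few. Any claim that something is new, unique, unknown or untested is made for them only; others in the source may bear on it.

Working notes on a short hydroxamic acid series. Compound 1 `CC(C)(C)c1ccc(CCCN2CC=C(CCC(=O)NO)C2=O)cc1` gives 3330 nM in a functional assay on ACHN cells (Homo sapiens) for inhibition, read by sulforhodamine B assay (a higher number here means a weaker inhibitor of growth, a lower number a stronger inhibitor of growth), compound 2 `Cc1ccc(CCCCN2CC=C(CCC(=O)NO)C2=O)cc1` gives 3730 nM in this assay, and compound 3 `O=C(CCC1=CCN(Cc2cccc(Br)c2)C1=O)NO` gives 3330 nM in this assay. Compound 3 is level with compound 1 at the digits shown, the two together holding the lowest of the three numbers; compound 2 is furthest from it, and that gap also lies within the scatter. The next compound, compound 4 `N#Cc1cccc(CN2CC=C(CCC(=O)NO)C2=O)c1`, is not yet measured. It differs from compound 3 by cyano in place of bromo on an aromatic carbon. Among the measured compounds shown here, no pair of measured compounds isolates this change, so its size is unknown from the data. The step of a 1.2-fold higher number from compound 3 to compound 4 (0.08 log units; within the scatter) is expected to be small, within the scatter, in no established direction. Compound 4 is estimated at 4000 nM in this assay, with a range of 1500 nM to 11000 nM.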

Compound 4, concentration for 50% growth inhibition: 7750 nM
Estimate against measurement, compound 4: 1.9-fold (0.29 log units) below; the range from low to high includes it.
By their numbers in this assay, from the lowest: compounds 1, 3 and 2 (each within the scatter of the next); then compound 4.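

Cyano in place of bromo on an aromatic carbon gives a 2.3-fold higher number from compound 3 to compound 4 (0.37 log units; beyond the scatter) in this assay. Among the compounds shown here, this is the first step that isolates a single change, and it shows that this position, meta to a large group, is not indifferent to the group it carries, although the effect is modest. Nothing available on these compounds accounts for the step.

As far as these compounds go, whether an amine, a methoxy group or a carboxylic acid at this position would follow bromo or cyano remains open. Also open, from the compounds shown here alone, is whether the same exchange gives a similar step on a longer chain, such as those of compound 1 and compound 2.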